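Urea-to-amide change at the terminal aryl of compound 2

The compounds below may be only part of what the source reports. "The series", "measured", "known", "first", "only" and "open" are said of these compounds alone.

Compound 1 `O=C(Nc1ccc(-n2cc(-c3ccncc3)c(-c3ccc(Cl)c(O)c3)n2)cc1)Nc1ccc(Cl)c(Cl)c1` and compound 2 `O=C(Nc1ccc(-n2cc(-c3ccncc3)c(-c3ccc(Cl)c(O)c3)n2)cc1)Nc1ccc(Cl)c(C(F)(F)F)c1` share a core and differ only at the outer ring of the urea. In a functional assay on A375P cells (Homo sapiens) for antiproliferative activity, read by MTT assay, with a stated time of 48 h (a lower number here means a stronger inhibitor, a higher number a weaker inhibitor), compound 1 gives 13500 nM; compound 2 gives 14900 nM, the higher of the two numbers, though the step of a 1.1-fold higher number from compound 1 to compound 2 (0.04 log units; within the scatter) is within the scatter. Compound 3 `O=C(Nc1ccc(-n2cc(-c3ccncc3)c(-c3ccc(Cl)c(O)c3)n2)cc1)c1cc(Cl)cc(Cl)c1` replaces the urea with an amide: 3,5-dichlorophenyl in place of (4-chloro-3-(trifluoromethyl)phenyl)amino on a carbonyl carbon. Within the data shown here, no measured step bears on this change; the single step from compound 1 to compound 2 alters only a substituent on the outer ring and leaves the urea intact, so it offers no guide to the size or direction of the effect. Among the measured compounds shown here, with both measured values weak and no precedent for the loss of the amide hydrogen, a modest shift toward a higher number, possibly within the scatter, is expected, a 1.5-fold higher number from compound 2 to compound 3 (0.17 log units; within the scatter). Compound 3 is estimated at 22000 nM, with a range of 7000 nM to 70000 nM in this assay.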

Compound 3, half-maximal inhibitory concentration: 6800 nM
Compound 3: middle estimate off by 3.2-fold (0.51 log units), on the high side; the whole stated range lies above it.
By their numbers in this assay, from the lowest: compounds 3, 1 and 2 (each within the scatter of the next, the first and the last beyond it).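

Replacing the urea with an amide at this carbonyl carbon does not weaken the series: in this assay the change gives a 2.2-fold lower number from compound 2 to compound 3 (0.34 log units; beyond the scatter) and a 2.0-fold lower number from compound 1 to compound 3 (0.30 log units; within the scatter), only the first of these steps lying beyond the scatter. Across compounds 1, 2 and 3, the urea nitrogen with its hydrogen is therefore not needed to retain activity at this position, unlike the earlier comparison, which left the urea in place. Nothing available explains this result.

Each of the two steps changes the link and the outer-ring substitution together, and the contribution of each stays unseparated. On these data alone, whether an amine or a carboxylic acid on the outer ring of the amide would shift the number further also remains open.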